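Semicarbazide extension of the aminoquinoline ureas

The source may hold more compounds than are shown below. What is called first, only, known or untested is meant among the compounds shown, and "the series" means these compounds.

Compound 1 `COc1cc(NC(C)CCCNC(=O)Nc2cccc(F)c2)c2ncccc2c1` gives 22000 nM in a functional assay on MIA PaCa-2 cells (Homo sapiens) for inhibition, read by MTT assay, with a stated time of 72 h (a higher number here means a weaker inhibitor, a lower number a stronger inhibitor), level at the digits shown with compound 3 `COc1cc(NC(C)CCCNC(=O)Nc2ccc(Cl)cc2)c2ncccc2c1` at 22000 nM; the step of no change at the digits printed from compound 1 to compound 3 (within the scatter) is within the scatter, and compound 1 and compound 3 together hold the lowest numbers here. Compound 2 `COc1cc(NC(C)CCCNC(=O)NNC(=O)Nc2ccc(Br)cc2)c2ncccc2c1` gives 231000 nM, the step of an 11-fold higher number from compound 1 to compound 2 (1.02 log units; beyond the scatter) being large. Compound 4 `COc1cc(NC(C)CCCNC(=O)NNC(=O)Nc2ccc(O)cc2)c2ncccc2c1` carries ((4-hydroxyphenyl)carbamoyl)amino in place of 3-fluorophenyl on an amide-type nitrogen. For the measured compounds named here, the only step that bears on this change is an 11-fold higher number from compound 1 to compound 2 (1.02 log units; beyond the scatter), where the same carbamoylamino insertion with a bromine-bearing ring weakened inhibition strongly; the hydroxyphenyl variant has no measured counterpart. A weakening of similar size is therefore expected, a 9.1-fold higher number from compound 1 to compound 4 (0.96 log units; beyond the scatter), so compound 4 is estimated at 200000 nM with a range of 70000 nM to 600000 nM in this assay.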

Compound 4, half-maximal inhibitory concentration: 142000 nM
The estimate for compound 4 lay 1.4-fold (0.15 log units) above the measured number; low and high end bracket the measured number.
By their numbers in this assay, from the lowest: compounds 1 and 3 (each within the scatter of the next); then compounds 4 and 2 (each within the scatter of the next).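

In this assay the carbamoylamino insertion also weakens inhibition with a hydroxy-bearing ring, giving a 6.5-fold higher number from compound 1 to compound 4 (0.81 log units; beyond the scatter) and a 6.5-fold higher number from compound 3 to compound 4 (0.81 log units; beyond the scatter) in the comparison with the other urea. On the extended chain, hydroxy in place of bromo gives a 1.6-fold lower number from compound 2 to compound 4 (0.21 log units; within the scatter) and does not separate the two ring substituents. No measured evidence bears on the cause of the weakening.

Open, from the compounds shown here alone, is whether an amine or a carboxylic acid on that ring would stand apart from hydroxy and bromo. Also open, going by these compounds, is the size of the insertion step with the ring held constant, as with ((4-chlorophenyl)carbamoyl)amino set against compound 3.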